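Swapping the 4-hydroxyphenyl group of compound 2

The compounds below may be only part of what the source reports. "The series", "measured", "known", "first", "only" and "open" are said of these compounds alone.

compound 1 `COc1ccc(-c2nnc(SCCCN3CCN(c4nc5ccccc5o4)CC3)o2)cc1` – 66100 nM
compound 2 `Oc1ccc(-c2nnc(SCCCN3CCN(c4nc5ccccc5o4)CC3)o2)cc1` – 502000 nM
compound 3 `O=C(NCc1nnc(SCCCN2CCN(c3nc4ccccc4o3)CC2)o1)c1ccccc1` – not yet measured

In a functional assay on HepG2 cells (Homo sapiens) for inhibition, read by MTT assay, with a stated time of 72 h (on this read-out higher numbers stand for weaker inhibition and lower numbers for stronger inhibition), compound 2 stands at 502000 nM and so holds the highest of the two numbers, making it the weaker of the pair. The next structure, compound 3, carries benzamidomethyl in place of 4-hydroxyphenyl on an aromatic carbon and keeps the rest of compound 2 unchanged.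

Among the compounds with values here, one measured step bears on this change. That step, a 7.6-fold higher number from compound 1 to compound 2 (0.88 log units; beyond the scatter), was modest and lay in the same substituent, with hydrogen in place of methyl on an oxygen on an aromatic ring. Within the data shown here, it shows that the number can move with this substituent, but no measured compound carries benzamidomethyl, so the size of this swap is not known directly. With compound 2 at the top and compound 1 at 66100 nM as the only other reference, a lower number is expected. The estimate in this assay is a 2.8-fold lower number from compound 2 to compound 3 (0.45 log units; beyond the scatter) as the expected step, no larger than the modest one already seen. Compound 3 is estimated at 180000 nM within a range of 50000 nM to 600000 nM for what the measurement may show.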

Compound 3, half-maximal inhibitory concentration: 88900 nM
For compound 3 the middle estimate is 2.0-fold (0.31 log units) above the measured one, and the stated range covers the measured number.
By their numbers in this assay, from the lowest: compounds 1 and 3 (each within the scatter of the next); then compound 2.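

In this assay, this position on the five-membered aromatic ring proves able to hold a group quite different from a substituted phenyl: benzamidomethyl in place of 4-hydroxyphenyl gives a 5.6-fold lower number from compound 2 to compound 3 (0.75 log units; beyond the scatter), a larger move than the one seen on removing the methyl from the oxygen. Set against 4-methoxyphenyl, the same group gives a 1.3-fold higher number from compound 1 to compound 3 (0.13 log units; within the scatter), so benzamidomethyl and 4-methoxyphenyl cannot be told apart here, and among the three compounds only the 4-hydroxyphenyl compound, compound 2, stands apart from the other two. Nothing available explains why the number moves with these groups at this position.

The compounds shown leave open which part of benzamidomethyl carries the change, since the amide, the methylene link and the phenyl ring all enter together, and a plain amine, a carboxylic acid or a longer chain at this position would help to separate them. They also leave open whether a chloro or methoxy group on the benzoyl ring would move the number beyond the scatter in this assay.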